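Chloro on the Fused Ring: A Second Look at the Step

A few compounds are considered here, and "the series" means these few. Any claim that something is new, unique, unknown or untested is made for them only; others in the source may bear on it.

Measured compounds:
Compound 1, `FC(F)(F)c1ccc(/C=C\c2cc3ccccc3nc2Cl)cc1`: 4260 nM
Compound 2, `FC(F)(F)c1ccc(/C=C\c2cc3ccc(Cl)cc3nc2Cl)cc1`: 6450 nM
Compound 3, `FC(F)(F)c1cc(/C=C\c2cc3ccccc3nc2Cl)cc(C(F)(F)F)c1`: 7460 nM

Of the compounds shown here, three have been tested in a functional assay on MCF7 cells (Homo sapiens) for antiproliferative activity, read by sulforhodamine B assay, with a stated time of 72 h; a lower number here means a stronger inhibitor, a higher number a weaker inhibitor. Compound 1 `FC(F)(F)c1ccc(/C=C\c2cc3ccccc3nc2Cl)cc1` gives 4260 nM. Compound 2 `FC(F)(F)c1ccc(/C=C\c2cc3ccc(Cl)cc3nc2Cl)cc1` differs from it in one place, (chloro in place of hydrogen on an aromatic carbon), and in this assay compound 2 gives 6450 nM; the step is a 1.5-fold higher number from compound 1 to compound 2 (0.18 log units; within the scatter). Compound 3 `FC(F)(F)c1cc(/C=C\c2cc3ccccc3nc2Cl)cc(C(F)(F)F)c1` rests on a different core; how the two cores differ is not broken down here. In this assay compound 3 gives 7460 nM, and its values against compound 1 and compound 2 lie within the usual scatter, so no ordering among the three is claimed.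

Compound 4 `FC(F)(F)c1cc(/C=C\c2cc3ccc(Cl)cc3nc2Cl)cc(C(F)(F)F)c1` has not yet been measured. It stands to compound 3 as compound 2 stands to compound 1: chloro in place of hydrogen on an aromatic carbon. The place of the change is described in the same words for both pairs, so this is the same change made on the second core. Among the compounds with values here, the only measured instance of it, a 1.5-fold higher number from compound 1 to compound 2 (0.18 log units; within the scatter), lay within the scatter. On that single precedent, compound 4 is expected to come out near compound 3, with a step of about a 1.3-fold higher number from compound 3 to compound 4 (0.13 log units; within the scatter) in this assay. The expected value for compound 4 is therefore 10000 nM, estimated to fall between 5000 nM and 22000 nM. Whether the second core carries the change the same way remains to be seen; one earlier pair gives only weak support.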

Compound 4, half-maximal inhibitory concentration: 41700 nM
Compound 4: the middle estimate sits 4.2-fold (0.62 log units) below what was measured, and the stated range ends below it.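

In this assay, putting chloro in place of hydrogen on the core of compound 3 gives a 5.6-fold higher number from compound 3 to compound 4 (0.75 log units; beyond the scatter), so on this core the change weakens the compound, whereas the earlier step on the core of compound 1, a 1.5-fold higher number from compound 1 to compound 2 (0.18 log units; within the scatter), supports no such claim. The same change therefore did not carry over from one core to the other at the same size, and the earlier pair proved a poor guide to the later one: the same change on two cores in this assay, a 1.5-fold higher number (0.18 log units; within the scatter) from compound 1 to compound 2 and a 5.6-fold higher number (0.75 log units; beyond the scatter) from compound 3 to compound 4, 3.7-fold (0.57 log units) apart, beyond the scatter of two such steps. Within the data shown here, this shows that, in this series, the size of the step depends on the core that carries it, but with only two pairs it gives no general rule for other cores and does not show which feature of the cores accounts for the gap.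

The compounds shown leave open whether a fluoro group, a methoxy group or an amine at the same place, on an aromatic carbon of the fused system, would behave on each core as chloro does. They also leave open how the same change would fare on a third core, and so whether either of the two steps seen here is the more typical one.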